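This account rests on a few compounds, and the source may have more. Where it says the series, first, only, none or still open, it means among the compounds named here.

Compound 2 `Nc1nc([SeH])nc2ncccc12` gives 37300 nM in a functional assay on MCF7 cells (Homo sapiens) for cytotoxicity, read by MTT assay, with a stated time of 72 h (on this read-out lower numbers stand for stronger inhibition of growth and higher numbers for weaker inhibition of growth), the second highest of the three numbers: compound 1 `CCCCC[Se]c1nc([Se]CCCCC)c2cccnc2n1` gives 40800 nM, within the scatter of it, while compound 3 `[SeH]c1nc([SeH])c2cccnc2n1` gives 9830 nM. Going by the values given here, the one single-point step known, a 3.8-fold lower number from compound 2 to compound 3 (0.58 log units; beyond the scatter), concerns a selenium in place of a nitrogen and does not touch the change at hand. Among the compounds with values here, compound 4 `CCCCC[Se]c1nc(N)c2cccnc2n1` carries pentyl in place of hydrogen on a selenium; no measured step isolates this pentylation. Compounds 1 and 3 differ by two such pentyls, and compound 1 shows the higher number, so a move towards weaker inhibition of growth is plausible but unanchored. A moderate rise, a 1.6-fold higher number from compound 2 to compound 4 (0.21 log units; within the scatter), is expected; compound 4 is estimated at 60000 nM, within 25000 nM to 150000 nM.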

Compound 4, concentration for 50% growth inhibition: 22700 nM
Compound 4: the middle estimate sits 2.6-fold (0.42 log units) above what was measured; measured number below the stated range.
By their numbers in this assay, from the lowest: compound 3; then compounds 4, 2 and 1 (each within the scatter of the next).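

In this assay the pentylation can now be read directly: a 1.6-fold lower number from compound 2 to compound 4 (0.22 log units; within the scatter) shows that pentyl in place of hydrogen on this selenium leaves the number within the scatter. The exchange of one nitrogen atom for the group of 6 heavy atoms, a 1.8-fold lower number from compound 1 to compound 4 (0.25 log units; within the scatter), likewise stays within the scatter, so neither change has a resolved effect on this read-out. No evidence on the reason for these results is available. Still open, going by these compounds, is whether a methyl group, a longer chain or a benzyl group on the selenium would also leave the number unmoved.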